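Working notes: replacing the 2,6-dibromopyridin-4-yl group

This account rests on a few compounds, and the source may have more. Where it says the series, first, only, none or still open, it means among the compounds named here.

In a functional assay on SW620/5-FU cells (Homo sapiens) for cytotoxicity, read by MTT assay, with a stated time of 48 h, in the presence of a further agent that is not named here (a lower number here means that less compound is needed, a higher number that more compound is needed for the effect), compound 1 (`COc1cc(NC(=O)NNc2cc(-c3ccccc3)c3cnn(C)c3n2)cc(Cl)n1`) gives 28700 nM and compound 2 (`COc1ccc(-c2cc(NNC(=O)Nc3cc(Br)nc(Br)c3)nc3c2cnn3C)cc1`) gives 54100 nM as its value. Among the compounds with values here, these two values lie within the scatter of each other, so compound 2 stands level with compound 1, and no measured step yet isolates a single change. Compound 3 (`COc1ccc(-c2cc(NNC(=O)Nc3cc(Cl)nc(OC)c3)nc3c2cnn3C)cc1`) follows from compound 2 through 2-chloro-6-methoxypyridin-4-yl in place of 2,6-dibromopyridin-4-yl on an amide-type nitrogen with 2-chloro-6-methoxypyridin-4-yl in place of 2,6-dibromopyridin-4-yl on an amide-type nitrogen. Within the data shown here, the entering group already occurs in compound 1, which gives 28700 nM as the only guide available. No change beyond the scatter is therefore expected in this assay and the estimate means a 1.5-fold lower number from compound 2 to compound 3 (0.18 log units; within the scatter) as a small drift at most. For compound 3 the estimate is 36000 nM with an expected range from 13000 nM to 95000 nM in this measurement.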

Compound 3, half-maximal effective concentration: 48800 nM
The estimate for compound 3 lay 1.4-fold (0.13 log units) below the measured number; measured number inside the range.
By their numbers in this assay, from the lowest: compounds 1, 3 and 2 (each within the scatter of the next).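

In this assay, within the data shown here, the first measured single change on the amide-type nitrogen, 2-chloro-6-methoxypyridin-4-yl in place of 2,6-dibromopyridin-4-yl, reads a 1.1-fold lower number from compound 2 to compound 3 (0.04 log units; within the scatter), so the two groups stand level at this position. The second single change, methoxy in place of hydrogen on an aromatic carbon, reads a 1.7-fold higher number from compound 1 to compound 3 (0.23 log units; within the scatter), so that difference also leaves the compounds level. No measured information bears on this result.

On these data alone, whether any change at either place can move the number beyond the scatter remains open. An amine or a carboxylic acid on the ring in place of chlorine or bromine would test this on the amide-type nitrogen side, and a longer chain than methoxy would test it on the aromatic carbon.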